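Working notes: bromo replacement from compound 2 to compound 4

The source may hold more compounds than are shown below. What is called first, only, known or untested is meant among the compounds shown, and "the series" means these compounds.

In a functional assay on SK-OV-3 cells (Homo sapiens) for antiproliferative activity, read by MTT assay, with a stated time of 72 h (a lower number here means a stronger inhibitor, a higher number a weaker inhibitor), compound 1 (`O=C(CCc1cccc2c1B(O)OC2)NCc1ccccc1`) reports > 100000 nM, which is a limit of the assay. Compound 2 (`O=C(CCc1cccc2c1B(O)OC2)Nc1ccc(Br)cc1`) gives 9200 nM, the higher of the two actual numbers. Compound 3 (`COc1ccc(NC(=O)CCc2cccc3c2B(O)OC3)cc1`) gives 900 nM. Compound 4 (`CC(C)(C)OC(=O)NCc1ccc(NC(=O)CCc2cccc3c2B(O)OC3)cc1`) carries ((tert-butoxycarbonyl)amino)methyl in place of bromo on an aromatic carbon. The step of an at least 10-fold lower number from compound 1 to compound 2 (1.03 log units; beyond the scatter) concerns the amide-type nitrogen and bears on this change only loosely. The closer guide replaces the same bromo with methoxy: a 10-fold lower number from compound 2 to compound 3 (1.01 log units; beyond the scatter). Going by the values given here, no measured compound carries the entering group, so a smaller step in the same direction is expected in this assay. The estimated step is a 3.1-fold lower number from compound 2 to compound 4 (0.49 log units; beyond the scatter). Compound 4 is estimated at 3000 nM, with an expected range of 500 nM to 15000 nM.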

Compound 4, half-maximal inhibitory concentration: 2000 nM
Estimate against measurement, compound 4: 1.5-fold (0.18 log units) above; measured number inside the range.
By their numbers in this assay, from the lowest: compound 3; then compound 4; then compound 2. At a limit, above all of these: compound 1.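

The aromatic carbon that held bromo accepts a far larger group without loss: ((tert-butoxycarbonyl)amino)methyl gives a 4.6-fold lower number from compound 2 to compound 4 (0.66 log units; beyond the scatter) and so still improves on bromo. The same group gives a 2.2-fold higher number from compound 3 to compound 4 (0.35 log units; beyond the scatter), so it falls short of methoxy, and heavy-atom count does not order these three compounds. The information at hand offers no explanation for either step.

As far as these compounds go, whether the activity depends on the tert-butoxycarbonyl cap remains open. A free aminomethyl group or a carboxylic acid on this carbon would test that.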